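The compounds below may be only part of what the source reports. "The series", "measured", "known", "first", "only" and "open" are said of these compounds alone.

Working notes on the series. Of the compounds shown here, two have been measured in an assay on CHO cells with metabotropic glutamate receptor 2 (Homo sapiens) as the target, read by FLIPR; a lower number here means that less compound is needed, a higher number that more compound is needed for the effect. Compound 1 `CCn1c(CN2CCN(c3ncc(Cl)cn3)CC2)nc2ccccc21` gives 158 nM in this assay. Compound 2 `Cn1c(CN2CCN(c3nc(Cl)ccc3C(F)(F)F)CC2)nc2ccc(F)cc21`, which carries a different core substitution pattern and a different aryl group on the piperazine, gives 126 nM in this assay; the two numbers lie within the usual scatter of each other, so neither can be set apart from the other.

Compound 3 `COCCn1c(CN2CCN(c3ncc(Cl)cn3)CC2)nc2ccccc21` has not been measured. It differs from compound 1 in one place: methoxy in place of hydrogen on a saturated chain carbon, two bonds along the chain from an aromatic nitrogen. Among the measured compounds shown here, no step between measured compounds that isolates this kind of change is available, so there is no measured precedent to lean on. The expectation for compound 3 is a step of a 1.1-fold lower number from compound 1 to compound 3 (0.02 log units; within the scatter) that stays within the scatter, in no firm direction. Compound 3 is therefore estimated at 150 nM in this assay, with a range from 60 nM to 400 nM.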

Compound 3, half-maximal effective concentration: 501 nM
Beside the measured number, compound 3's estimate is 3.3-fold (0.52 log units) below it, and the stated range ends below it.
By their numbers in this assay, from the lowest: compounds 2 and 1 (each within the scatter of the next); then compound 3.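

In this assay, among the compounds shown here, the change from ethyl to 2-methoxyethyl is a 3.2-fold higher number from compound 1 to compound 3 (0.50 log units; beyond the scatter) and is the only step that isolates a single change. It shows that this chain is not indifferent to substitution: with methoxy in place of hydrogen at this carbon, more compound is needed for the effect, something the earlier pair could not show, as compound 1 and compound 2 differ in more than one place. Nothing available bears on why the number moves.

Still open, on these data alone, is whether the step belongs to the oxygen or simply to the longer chain, which a propyl, butyl, 2-hydroxyethyl or 2-aminoethyl group on the same aromatic nitrogen could separate. Also open, as far as these compounds go, is whether the change would give a step of similar size on compound 2, which carries a different aryl group on the piperazine.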